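Swapping a six-carbon chain for tert-butyl on the imine nitrogen

The compounds below may be only part of what the source reports. "The series", "measured", "known", "first", "only" and "open" are said of these compounds alone.

Of the compounds shown here, three sharing a small core have been tested in a functional assay for inhibition, with Rattus norvegicus as the target; on this read-out lower numbers stand for stronger inhibition and higher numbers for weaker inhibition. Compound 1, `CC(/N=c1\c(O)c(O)\c1=N/c1cccnc1)C(C)(C)C`, gives 1950 nM in this assay. Compound 2, `CC(C)(C)/N=c1\c(O)c(O)\c1=N/c1cccnc1`, gives 2800 nM. Within the data shown here, the only change between them is tert-butyl in place of 1,2,2-trimethylpropyl on a double-bonded nitrogen, and the step of a 1.4-fold higher number from compound 1 to compound 2 (0.16 log units; within the scatter) is small enough to count as no change at all.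

Compound 3, `CC(/N=c1\c(O)c(O)\c1=N/c1ccc(C#N)cc1)C(C)(C)C`, gives 520 nM, the lowest number of the three and beyond the scatter from both compound 1 and compound 2. Compound 3 carries the same 1,2,2-trimethylpropyl group as compound 1 but a different aromatic part on the other double-bonded nitrogen; the difference between the two cores is not broken down here.

Compound 4, `CC(C)(C)/N=c1\c(O)c(O)\c1=N/c1ccc(C#N)cc1`, has not yet been measured. It differs from compound 3 by tert-butyl in place of 1,2,2-trimethylpropyl on a double-bonded nitrogen, the same change that was made from compound 1 to compound 2 at an identical place. Because that earlier change produced a 1.4-fold higher number from compound 1 to compound 2 (0.16 log units; within the scatter), the step from compound 3 to compound 4 is expected to be comparably small, roughly a 1.4-fold higher number from compound 3 to compound 4 (0.15 log units; within the scatter). On that basis compound 4 is estimated to give about 730 nM in this assay, with a likely range from 350 nM to 1600 nM.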

Compound 4, half-maximal inhibitory concentration: 560 nM
Estimate against measurement, compound 4: 1.3-fold (0.12 log units) above; measured number inside the range.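

Replacing 1,2,2-trimethylpropyl with tert-butyl on the core of compound 3 makes no real difference in this assay, with a 1.1-fold higher number from compound 3 to compound 4 (0.03 log units; within the scatter). Set beside the earlier step, the change behaves alike on both cores, since neither step stands out from the ordinary scatter of repeated measurements and the two steps do not differ from each other: the same change on two cores in this assay, a 1.4-fold higher number (0.16 log units; within the scatter) from compound 1 to compound 2 and a 1.1-fold higher number (0.03 log units; within the scatter) from compound 3 to compound 4, 1.3-fold (0.12 log units) apart, within the scatter of two such steps. This shows only that, on these two cores and in this one read-out, the six-carbon group can give way to the four-carbon group without a step beyond the scatter; it does not show that the same would hold on any other core, or that the two groups would match in any other kind of test.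

Both groups compared here are all-carbon and contain no ring, so the compounds shown leave open what a cyclohexyl ring, a longer chain, an amine or a carboxylic acid would do on the same double-bonded nitrogen. They also leave open whether the swap would stay this quiet with an aromatic part other than the two seen here.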